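The source may report more compounds than this note shows. Statements on the series, on what has been measured and on what is new or still open speak of the compounds shown alone.

Compound 1 `C[C@@H](C(=O)O)c1nn(Cc2cn3cc(OCC4CC4)c(Cl)cc3n2)c2ccccc2c1=O` gives the higher of the two numbers recorded in a functional assay on HFL1 cells for antagonist activity at sphingosine 1-phosphate receptor 2 (Homo sapiens), read by ELISA, with a stated time of 24 h (a lower number here means a stronger inhibitor, a higher number a weaker inhibitor), where compound 1 shows 182 nM. Going by the values given here, its only measured neighbour is compound 2 `COC(C(=O)O)c1nn(Cc2cn3cc(OCC4CC4)c(Cl)cc3n2)c2ccccc2c1=O`, which in this assay shows 94 nM. Among the compounds with values here, the single measured step, a 1.9-fold lower number from compound 1 to compound 2 (0.29 log units; within the scatter), exchanges one small substituent on the same carbon for another and stays within the scatter. Compound 3 `CC(C)(C(=O)O)c1nn(Cc2cn3cc(OCC4CC4)c(Cl)cc3n2)c2ccccc2c1=O` has not yet been measured; it differs from compound 1 in that (1-carboxy-1-methylethyl in place of 1-carboxyethyl on an aromatic carbon). Within the data shown here, this change again touches only the small group on that carbon, and the one step that bears on such changes, a 1.9-fold lower number from compound 1 to compound 2 (0.29 log units; within the scatter), did not move the number beyond the scatter. Compound 3 is therefore expected to give a number close to that of compound 1, with the step of a 1.4-fold higher number from compound 1 to compound 3 (0.14 log units; within the scatter) expected to remain within the scatter. For compound 3 the estimate in this assay is 250 nM, with a range from 80 nM to 800 nM.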

Compound 3, half-maximal inhibitory concentration: 21 nM
For compound 3 the middle estimate is 12-fold (1.08 log units) above the measured one; measured number below the stated range.
By their numbers in this assay, from the lowest: compound 3; then compounds 2 and 1 (each within the scatter of the next).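

In this assay, the position on the aromatic carbon next to the ring nitrogen proves sensitive to a small change after all: replacing 1-carboxyethyl with 1-carboxy-1-methylethyl gives an 8.7-fold lower number from compound 1 to compound 3 (0.94 log units; beyond the scatter), whereas the earlier step stayed within the scatter. The same group also compares well with carboxy(methoxy)methyl, with a 4.5-fold lower number from compound 2 to compound 3 (0.65 log units; beyond the scatter), and of the groups compared here only 1-carboxy-1-methylethyl carries no defined stereocentre. Nothing measured here accounts for these differences.

The compounds leave open whether the opposite stereoisomer of compound 1 would differ from compound 1, and so whether the stereocentre has any bearing on the result. They also leave open how a 1-carboxycyclopropyl group, a longer chain such as ethyl on the same carbon, or an amide in place of the carboxylic acid would read.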